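Pyrazole chalcones: aminophenyl to dichlorophenyl swap

The source may report more compounds than this note shows. Statements on the series, on what has been measured and on what is new or still open speak of the compounds shown alone.

Measured so far:
compound 1 `COc1cc(-c2cc(/C=C/C(=O)c3ccc(N)cc3)[nH]n2)cc(OC)c1OC`: 98%
compound 2 `COc1ccc(-c2cc(/C=C/C(=O)c3ccc(OC)c(OC)c3)[nH]n2)cc1`: 106%

Two compounds of this series have numbers in a functional assay on RPMI-8226 cells (Homo sapiens) for cytotoxicity, read by sulforhodamine B assay, with a stated time of 48 h, tested at 0.01 uM; on this read-out higher numbers stand for a weaker effect at the one concentration tested and lower numbers for a stronger effect. Compound 1 gives 98% there, and compound 2 gives 106%. The gap between the two lies within the usual scatter of such measurements, so they cannot be told apart; at the single concentration tested, neither shows more than a marginal effect on the cells. Within the data shown here, no pair of measured compounds differs in one place only, so no single structural step has yet been sized.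

Compound 3 `COc1cc(-c2cc(/C=C/C(=O)c3ccc(Cl)c(Cl)c3)[nH]n2)cc(OC)c1OC` is not yet measured. Its difference from compound 1 is 3,4-dichlorophenyl in place of 4-aminophenyl on a carbonyl carbon: the 4-aminophenyl leaves and a 3,4-dichlorophenyl enters, both on the carbonyl carbon whose other neighbour is the double-bonded chain carbon. Nothing in the measured pair bears on this swap, and both measured numbers sit at the inactive end of the read-out.

The step of a number 1 percentage points lower from compound 1 to compound 3 (within the scatter) is expected to stay within the scatter, in no clear direction. Compound 3 is therefore estimated at 97% in this assay, with a range from 80% to 110%.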

Compound 3, a percentage reported as activity, at one concentration (the size of the read-out at that concentration, not a potency): 100%
For compound 3 the middle estimate is 3 percentage points below the measured one; the range from low to high includes it.
By their numbers in this assay, from the lowest: compounds 1, 3 and 2 (each within the scatter of the next).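

In this assay, placing 3,4-dichlorophenyl instead of 4-aminophenyl on the carbonyl carbon gives a number 2 percentage points higher from compound 1 to compound 3 (within the scatter), the first single-place step sized in this series. The hydrogen-bond donor and acceptor counted on the 4-aminophenyl are absent from the 3,4-dichlorophenyl, yet this exchange of two quite different groups produces no readable change at the one concentration tested; with compound 3 at 100%, however, the pair remains at the inactive end of the read-out, so the flat step shows no tolerance or preference at this position in any wider sense. No measurement at hand bears on the reason for this result.

As far as these compounds go, whether 4-aminophenyl and 3,4-dichlorophenyl would separate at a concentration where the compounds clearly act on the cells remains open. Also open, from the compounds shown here alone, is how the series would respond to a quite different group on the carbonyl carbon, such as a phenyl ring carrying a carboxylic acid, while compound 2 differs from the others in more than one place, so steps to it cannot be read.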